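Swapping methoxy for bromo in compound 2

The source may hold more compounds than are shown below. What is called first, only, known or untested is meant among the compounds shown, and "the series" means these compounds.

Compound 1 `Cc1ccc(-c2c(CN3CCCCC3)nc3scc(C(=O)O)n23)cc1` gives 10800 nM
Compound 2 `COc1ccc(-c2c(CN3CCCCC3)nc3scc(C(=O)O)n23)cc1` gives 75100 nM

In a functional assay on HepG2 cells (Homo sapiens) for antiproliferative activity, read by MTT assay, with a stated time of 72 h (on this read-out lower numbers stand for stronger inhibition and higher numbers for weaker inhibition), compound 2 gives 75100 nM as the higher of the two numbers. Compound 3 `O=C(O)c1csc2nc(CN3CCCCC3)c(-c3ccc(Br)cc3)n12` carries one change, bromo in place of methoxy on an aromatic carbon with bromo in place of methoxy on an aromatic carbon. Among the measured compounds shown here, the only measured step at this place is a 7.0-fold higher number from compound 1 to compound 2 (0.84 log units; beyond the scatter) for methoxy in place of methyl, a modest one. For the measured compounds named here, no bromo compound has been measured, so that step is a thin guide. The estimated step in this assay is a 3.0-fold lower number from compound 2 to compound 3 (0.48 log units; beyond the scatter) and is expected to be modest, towards a lower number. For compound 3 the expected value is 25000 nM within an estimated range from 8000 nM to 80000 nM as its upper end.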

Compound 3, half-maximal inhibitory concentration: > 100000 nM
Compound 3: no number, only a limit; the forecaster's own chance of this, stated with the estimate: 3%; middle value at least 4.0-fold (0.60 log units) from the limit.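

In this assay compound 3 gives only a limit, not a number: the limit of > 100000 nM in this assay, at which 1 of the 3 values shown sits. Set against the methoxy group, bromo gives an at least 1.3-fold higher number from compound 2 to compound 3 (0.12 log units; that floor lies within the scatter), so the two groups cannot be told apart on this floor alone. Set against the methyl group, bromo gives an at least 9.2-fold higher number from compound 1 to compound 3 (0.96 log units; beyond the scatter), so both replacements of methyl at this place on the aromatic ring end with higher numbers. As far as these compounds go, how far compound 3 really lies from compound 2 stays open. So does whether an amine or a hydroxyl group at this place would give a number lower than that of compound 1.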